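The compounds below may be only part of what the source reports. "The series", "measured", "known", "first", "only" and "open" are said of these compounds alone.

Compound 1 `N#Cc1ccc(-c2nc(C(c3ccc(F)cc3)c3ccc(F)cc3)sc2CC(=O)O)cc1`: 30% in an in vitro functional assay on HEK285-7 cells for antagonist activity at prostaglandin D2 receptor 2 (Homo sapiens), read by BRET and beta-arrestin recruitment; a higher number here means a larger maximal response, a lower number a smaller maximal response.
Compound 2 `O=C(O)Cc1sc(C(c2ccc(F)cc2)c2ccc(F)cc2)nc1-c1cc(F)cc(F)c1`: 80% in this assay.

Compound 2 holds the higher of these two numbers; its nearest neighbour is compound 1, and the step of a number 50 percentage points higher from compound 1 to compound 2 (beyond the scatter) lies beyond the scatter. Compound 3 `O=C(O)Cc1sc(C(c2ccc(F)cc2)c2ccc(F)cc2)nc1-c1ccccc1` differs from compound 2 in one place: phenyl in place of 3,5-difluorophenyl on an aromatic carbon. Among the measured compounds shown here, only that one measured step bears on the new change, since it altered the same aryl group, and it was large, though it does not directly address loss of the two fluorines. A moderate decrease in this assay is therefore expected, a number 15 percentage points lower from compound 2 to compound 3 (beyond the scatter). Compound 3 is estimated at 65%, with a range from 40% to 90%.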

Compound 3, largest response reached (reported as efficacy), in percent of the reference or control that the assay uses: 80%
Compound 3: the middle estimate sits 15 percentage points below what was measured; the measured number falls inside the stated range.
By their numbers in this assay, from the lowest: compound 1; then compounds 2 and 3 (each within the scatter of the next).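

In this assay, phenyl in place of 3,5-difluorophenyl gives no change at the digits printed from compound 2 to compound 3 (within the scatter) and shows that the higher response at this position does not depend on the two fluorines. Hydrogen in place of cyano gives a number 50 percentage points higher from compound 1 to compound 3 (beyond the scatter) and ties the lower response of compound 1 to its cyano group, rather than to the absence of fluorines. Nothing available explains this difference. Still open, as far as these compounds go, is whether a methoxy group or an amine at the cyano position would also lower the response, or whether this is particular to the nitrile.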